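A few compounds are considered here, and "the series" means these few. Any claim that something is new, unique, unknown or untested is made for them only; others in the source may bear on it.

Measured so far in a functional assay on the whole organism with Rattus norvegicus as the target, at a dose of 100 mg/kg; a lower number here means less inhibition, a higher number more inhibition at the dose given (going by the name of the read-out):
- compound 1 `N#CNC(=N)NCCCCCn1nc(-c2ccccc2)ccc1=O`: 31%
- compound 2 `C/N=C(/NC#N)NCCCCCn1nc(-c2ccccc2)ccc1=O`: 47.6%
- compound 3 `CC(C)(C)/N=C(\S)NCCCCn1nc(-c2ccccc2)ccc1=O`: 33.6%

Compound 2 stands highest of the three numbers. The nearest is compound 3, with a number 14 percentage points lower from compound 2 to compound 3 (beyond the scatter); the furthest is compound 1, with a number 16.6 percentage points higher from compound 1 to compound 2 (beyond the scatter) in the other direction. Compound 1 and compound 3 sit close together, a number 2.6 percentage points higher from compound 1 to compound 3 (within the scatter).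

Compound 4 `C/N=C(/NC#N)NCCCCCn1nc(-c2ccccc2)c(C)cc1=O` is compound 2 with methyl in place of hydrogen on an aromatic carbon. Every measured step in the series changes the chain end or its terminal group: the terminal amine substituent in the step from compound 1 to compound 2, and the terminal group on the chain in the steps into compound 3. Among the compounds with values here, none touches the six-membered aromatic ring with 2 nitrogen of the shared core, so no measured step bears on this change. Within the data shown here, the only grounding is the value of compound 2 itself, 47.6%; with no step to lean on, the expectation is for no shift beyond the scatter, a number 0.6 percentage points lower from compound 2 to compound 4 (within the scatter). Compound 4 is estimated at 47%, with a range from 30% to 63%.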

Compound 4, a percentage reported as inhibition, in the whole organism at one dose (the size of the read-out at that dose, not a potency): 28.5%
Compound 4: middle estimate off by 18.5 percentage points, on the high side; the measured number lies below the stated range.
By their numbers in this assay, from the lowest: compounds 4, 1 and 3 (each within the scatter of the next); then compound 2.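

In this assay, the step from hydrogen to methyl on this aromatic carbon, ortho to a phenyl group, gives a number 19.1 percentage points lower from compound 2 to compound 4 (beyond the scatter). Within the data shown here, this is the first measured step on the ring of the shared core, and it shows that the read-out depends on this position as well as on the chain end, the only part changed in steps such as a number 16.6 percentage points higher from compound 1 to compound 2 (beyond the scatter). Nothing measured in the series gives a reason for this drop.

As far as these compounds go, it remains open whether an ethyl group or a chlorine atom on this same carbon would give a step of similar size or direction. From the compounds shown here alone, it is also open whether methyl here would lower the number to the same degree with the terminal group of compound 1 or compound 3.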